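Fluoro for methyl on the benzyloxy arm of compound 2

The compounds below may be only part of what the source reports. "The series", "measured", "known", "first", "only" and "open" are said of these compounds alone.

Compound 1 `Cc1ccc(NC(=O)NC(=O)c2ccc(OCc3ccc(F)cc3)cc2)cc1-c1nc2ccccc2[nH]1`: 35100 nM
Compound 2 `Cc1ccc(COc2ccc(C(=O)NC(=O)Nc3ccc(Cl)c(-c4nc5ccccc5[nH]4)c3)cc2)cc1`: 23200 nM

Two acylurea compounds have been measured in a functional assay on SW-620 cells (Homo sapiens) for inhibition, read by MTT assay, with a stated time of 48 h; a higher number here means a weaker inhibitor, a lower number a stronger inhibitor. Compound 1 gives 35100 nM in this assay. Compound 2 gives 23200 nM in this assay, the lower of the two numbers, although the gap to compound 1 is within the usual scatter, so the two cannot be ordered. Among the compounds with values here, no single-point step connects them, as they differ in more than one place.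

Compound 3 `O=C(NC(=O)c1ccc(OCc2ccc(F)cc2)cc1)Nc1ccc(Cl)c(-c2nc3ccccc3[nH]2)c1` has not yet been measured. It differs from compound 2 by fluoro in place of methyl on an aromatic carbon. Within the data shown here, no measured pair shows this exact change, and the only other fluorobenzyl compound, compound 1, carries a different substituent elsewhere. A change of this size is expected to move this assay little, so the step from compound 2 to compound 3 is estimated at a 1.2-fold higher number from compound 2 to compound 3 (0.08 log units; within the scatter), within the scatter. Compound 3 is therefore expected to give about 28000 nM, with a range from 12000 nM to 65000 nM.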

Compound 3, half-maximal inhibitory concentration: 33600 nM
Beside the measured number, compound 3's estimate is 1.2-fold (0.08 log units) below it; the measured number falls inside the stated range.
By their numbers in this assay, from the lowest: compounds 2, 3 and 1 (each within the scatter of the next).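

In this assay, within the data shown here, the step of a 1.4-fold higher number from compound 2 to compound 3 (0.16 log units; within the scatter) gives the first direct reading of fluoro in place of methyl on this aromatic carbon, para to a large group, and the two groups cannot be told apart here. Among these compounds, with the 4-fluorobenzyl arm held fixed, the step of a 1.0-fold lower number from compound 1 to compound 3 (0.02 log units; within the scatter) gives the first reading of chloro in place of methyl on the other aromatic ring, and those two groups cannot be told apart either. No other measurement bears on these results.

The compounds shown leave open whether any group at this position moves the number beyond the scatter, since only methyl and fluoro appear there. An amine, a carboxylic acid or a longer chain in place of the fluoro would test this.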